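A Shorter Oxygen-Bearing Chain on the Ring Nitrogen

This account rests on a few compounds, and the source may have more. Where it says the series, first, only, none or still open, it means among the compounds named here.

The measured compounds and their values:
compound 1 `CC(C)CCn1c(N2CCN(C)CC2)nc2ccccc21` gives 1400 nM in a functional assay on ileum for inhibition of histamine H1 receptor (Cavia porcellus); on this read-out lower numbers stand for stronger inhibition and higher numbers for weaker inhibition
compound 2 `CCCC(C)n1c(N2CCN(C)CC2)nc2ccccc21` gives 1400 nM in this assay
compound 3 `CCOCCn1c(N2CCCN(Cc3ccccc3)CC2)nc2ccccc21` gives 15 nM in this assay

Compound 2 stands level with compound 1 at the digits shown, and the two together hold the highest numbers of the three. Compound 3 sits well below them, a gap beyond the scatter, but compound 3 differs from compound 2 in more than the chain on the ring nitrogen, so its value alone cannot be tied to that chain.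

Compound 4 `COCCn1c(N2CCN(C)CC2)nc2ccccc21` is the compound still to be measured. It differs from compound 2 in one place: 2-methoxyethyl in place of 1-methylbutyl on an aromatic nitrogen.

For the measured compounds named here, the only step that bears on a change at this position is no change at the digits printed from compound 1 to compound 2 (within the scatter), which shows that swapping one branched five-carbon chain for another left the number where it was. Going by the values given here, no step shows a chain carrying oxygen at this position with the rest of compound 2 unchanged. On that basis the expected step of a 1.4-fold lower number from compound 2 to compound 4 (0.15 log units; within the scatter) is small, and none beyond the scatter is the likeliest outcome, with a wide range to allow for the unknown effect of the new chain. For compound 4 the estimated value in this assay is 1000 nM, within 250 nM to 4000 nM.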

Compound 4, half-maximal inhibitory concentration: 13 nM
Estimate against measurement, compound 4: 77-fold (1.89 log units) above; measured number outside the range, below it.
By their numbers in this assay, from the lowest: compounds 4 and 3 (each within the scatter of the next); then compounds 1 and 2 (each within the scatter of the next).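

In this assay, 2-methoxyethyl in place of 1-methylbutyl on the aromatic nitrogen gives a 110-fold lower number from compound 2 to compound 4 (2.03 log units; beyond the scatter), and methoxy in place of isopropyl on the saturated chain carbon, two bonds along the chain from that nitrogen, gives a 110-fold lower number from compound 1 to compound 4 (2.03 log units; beyond the scatter), so both routes to compound 4 end in a large drop. The earlier step, no change at the digits printed from compound 1 to compound 2 (within the scatter), compared only two chains of carbon and hydrogen and left the position looking indifferent, whereas the new steps show that the number in this assay can move a long way with the group placed there. No measurement given here accounts for the size of this drop.

The new chain brings in an oxygen and is also one heavy atom smaller, and the compounds shown do not separate those two changes, which a plain butyl chain or a 3-methoxypropyl chain on the same nitrogen could begin to do. Also open, going by these compounds, are whether a 2-hydroxyethyl chain would serve as well as 2-methoxyethyl, and whether the low number would hold with a 4-ethylpiperazin-1-yl group in place of the 4-methylpiperazin-1-yl group.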